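A Ring Closes Where a Chain Stood

This account rests on a few compounds, and the source may have more. Where it says the series, first, only, none or still open, it means among the compounds named here.

Of the compounds shown here, two built on the same core have been tested in a functional assay on MCF7 cells (Homo sapiens) for antiproliferative activity; a higher number here means a weaker inhibitor, a lower number a stronger inhibitor. Compound 1 `CCC(C)Cn1c(Cc2cc(OC)c(OC)c(OC)c2)nc2c(N)ncnc21` gives 61700 nM in this assay, and compound 2 `COCCn1c(Cc2cc(OC)c(OC)c(OC)c2)nc2c(N)nc(F)nc21` gives 64600 nM. The two numbers lie within the usual scatter of each other, so neither compound can be placed ahead of the other; both sit at the weak end of what this assay reports. Within the data shown here, no pair of measured compounds differs in one place only, so no single structural step has yet been measured.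

Compound 3 `COc1cc(Cc2nc3c(N)ncnc3n2CC2CCC2)cc(OC)c1OC` has not yet been tested. It differs from compound 1 as follows: cyclobutyl in place of sec-butyl on a saturated chain carbon bound to an aromatic nitrogen. The group that leaves and the group that enters are alike in size; what changes is that a chain without a ring gives way to a four-membered ring. Among the measured compounds shown here, nothing measured so far shows how such a swap moves the number in this assay. A step of about a 1.0-fold lower number from compound 1 to compound 3 (0.01 log units; within the scatter) is therefore expected, no larger than the scatter, with no clear direction. On that basis compound 3 is estimated to give about 60000 nM in this assay, most likely between 25000 nM and 150000 nM.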

Compound 3, half-maximal inhibitory concentration: 45700 nM
Estimate against measurement, compound 3: 1.3-fold (0.12 log units) above; the range from low to high includes it.
By their numbers in this assay, from the lowest: compounds 3, 1 and 2 (each within the scatter of the next).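

Swapping sec-butyl for cyclobutyl gives the first single-place comparison in this series: in this assay, the change is a 1.4-fold lower number from compound 1 to compound 3 (0.13 log units; within the scatter). At this position on a saturated chain carbon bound to an aromatic nitrogen, then, closing an open chain of four carbons into a four-membered ring of the same heavy-atom count has no effect that can be told apart from the scatter, and compound 3, at 45700 nM, stays in the same weak range as compound 1. No other measurement is available to explain this result.

Among these compounds, this single step covers only two all-carbon groups of the same heavy-atom count, so it remains open whether a different group at this position, such as an amine, a carboxylic acid or a longer chain, would shift the number beyond the scatter. Going by these compounds, it also remains open whether a change elsewhere in the molecule, such as a hydroxyl in place of a methoxy group, would do more than either of these carbon groups.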